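The source may report more compounds than this note shows. Statements on the series, on what has been measured and on what is new or still open speak of the compounds shown alone.

Measured in a functional assay on MCF7 cells (Homo sapiens) for antiproliferative activity, read by MTT assay, with a stated time of 72 h; on this read-out higher numbers stand for weaker inhibition and lower numbers for stronger inhibition: compound 1 `C/C=C/C(=O)Nc1cc2c(N3CCc4ccccc43)ncnc2cc1OC` gives 4030 nM; compound 2 `COc1cc2ncnc(N3CCc4ccccc43)c2cc1NC(=O)/C=C/CN(C)C` gives 3370 nM; compound 3 `COc1cc2ncnc(N3CCc4ccccc43)c2cc1NC(=O)/C=C/CN1CCCC1` gives 1510 nM.

Compound 3 has the lowest number of the three: the steps of a 2.7-fold lower number from compound 1 to compound 3 (0.43 log units; beyond the scatter) and a 2.2-fold lower number from compound 2 to compound 3 (0.35 log units; beyond the scatter) both lie beyond the scatter, while a 1.2-fold lower number from compound 1 to compound 2 (0.08 log units; within the scatter) does not. Compound 4 `COc1cc2ncnc(N3CCc4ccccc43)c2cc1NC(=O)/C=C/CN1CCN(C)CC1` differs from compound 3 by 4-methylpiperazin-1-yl in place of pyrrolidin-1-yl on a saturated chain carbon bound to a double-bonded chain carbon. For the measured compounds named here, no measured step exchanges one ring amine for another; the nearest comparison is the modest gain on going from dimethylamino to pyrrolidin-1-yl, and these compounds do not show whether a six-membered ring with 2 hetero atoms repeats it. The expected step is therefore a 1.2-fold higher number from compound 3 to compound 4 (0.08 log units; within the scatter), not beyond the scatter. Compound 4 in this assay is estimated at 1800 nM, between 700 nM and 4500 nM.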

Compound 4, half-maximal inhibitory concentration: 6430 nM
The estimate for compound 4 lay 3.6-fold (0.55 log units) below the measured number, outside the stated range (above it).
By their numbers in this assay, from the lowest: compound 3; then compounds 2, 1 and 4 (each within the scatter of the next).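

The ring amine on this saturated chain carbon cannot be exchanged freely: 4-methylpiperazin-1-yl in place of pyrrolidin-1-yl gives (a 4.3-fold higher number from compound 3 to compound 4 (0.63 log units; beyond the scatter)) in this assay and removes the gain seen with pyrrolidin-1-yl. Both other steps stay within the scatter (a 1.9-fold higher number from compound 2 to compound 4 (0.28 log units; within the scatter); a 1.6-fold higher number from compound 1 to compound 4 (0.20 log units; within the scatter)), so only pyrrolidin-1-yl stands apart from the other groups at this place. Nothing available here explains the difference.

As far as these compounds go, it remains open whether the six-membered ring, the second ring nitrogen or its methyl carries the loss. Piperidin-1-yl, morpholin-4-yl and unsubstituted piperazin-1-yl could separate these.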